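Swapping chloro for methyl on the side-chain amide series

This account rests on a few compounds, and the source may have more. Where it says the series, first, only, none or still open, it means among the compounds named here.

Measured in a functional assay on the whole organism for inhibition, with Mus musculus as the target; a lower number here means that less compound is needed, a higher number that more compound is needed for the effect:
Compound 1 `Cc1ccc(C2CN(C)Cc3c(N)cccc32)cc1`: about 1.2 mg/kg
Compound 2 `CCCCNC(=O)Nc1cccc2c1CN(C)CC2c1ccc(Cl)cc1`: 15 mg/kg
Compound 3 `CCCCNCC(=O)Nc1cccc2c1CN(C)CC2c1ccc(Cl)cc1`: 3.9 mg/kg

Compound 3 has the second highest of the three numbers, with compound 2 higher and compound 1 lower. Compound 4 `CCCCNCC(=O)Nc1cccc2c1CN(C)CC2c1ccc(C)cc1` alters compound 3 in one place: methyl in place of chloro on an aromatic carbon. The 4-chlorophenyl group thus becomes 4-methylphenyl. Among the compounds with values here, no measured step covers this change. The only one, a 3.8-fold lower number from compound 2 to compound 3 (0.59 log units; beyond the scatter), concerns a different part of the molecule. Compound 1 also carries 4-methylphenyl, but it differs elsewhere too, so its value cannot isolate this swap. Nothing measured points either way, so the expected size in this assay is nothing beyond the scatter, and the estimated step is a 1.1-fold lower number from compound 3 to compound 4 (0.05 log units; within the scatter). Compound 4 is expected at about 3.5 mg/kg, with an estimated range of 1.5 mg/kg to 8.5 mg/kg.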

Compound 4, dose for half-maximal effect: about 2.5 mg/kg
The estimate for compound 4 lay 1.4-fold (0.15 log units) above the measured number; low and high end bracket the measured number.
By their numbers in this assay, from the lowest: compound 1; then compounds 4 and 3 (each within the scatter of the next); then compound 2.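

In this assay, changing 4-chlorophenyl to 4-methylphenyl gives a 1.6-fold lower number from compound 3 to compound 4 (0.19 log units; within the scatter), so at this position, para to a large group, chloro and methyl cannot be told apart. With 4-methylphenyl held constant, the side chain can now be read alone: placing ((butylamino)methyl)carbonyl on the nitrogen on the aromatic ring gives a 2.1-fold higher number from compound 1 to compound 4 (0.32 log units; beyond the scatter), a modest step. No measurement here explains either result. The compounds shown leave open whether methoxy or trifluoromethyl at this position would fit the same picture, and what a longer chain on the side-chain amine would do.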